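Aryl ether variation and MOLT-3 cytotoxicity on a shared core

The source may hold more compounds than are shown below. What is called first, only, known or untested is meant among the compounds shown, and "the series" means these compounds.

Measured so far:
Compound 1 `Cc1ccc(OCc2cn(-c3ccc(S(=O)(=O)N4CCc5ccccc5C4)cc3)nn2)cc1` gives > 50 ug/mL in a functional assay on MOLT-3 cells (Homo sapiens) for cytotoxicity, read by MTT assay, with a stated time of 48 h; a lower number here means a stronger inhibitor, a higher number a weaker inhibitor; this is a limit of the assay, not a number.
Compound 2 `COc1cc2c(cc1OC)CN(S(=O)(=O)c1ccc(-n3cc(COc4ccc([N+](=O)[O-])cc4)nn3)cc1)CC2` gives > 50 ug/mL in this assay, again a limit.
Compound 3 `COc1cc2c(cc1OC)CN(S(=O)(=O)c1ccc(-n3cc(COc4ccccc4C)nn3)cc1)CC2` gives > 50 ug/mL in this assay, again a limit.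

Compound 1 therefore stands at the limit of the assay, and all of the values shown sit there too (the limit of > 50 ug/mL in this assay, at which 3 of the 3 values shown sit). For the measured compounds named here, the one measured step that changes the aryl ether, a step that the two limits leave unreadable from compound 2 to compound 3, is a step that the two limits leave unreadable: the values of compound 2 and compound 3 both sit at the limit, so its size cannot be told.

The unmeasured compound 4 `O=S(=O)(c1ccc(-n2cc(COc3ccc4ccccc4c3)nn2)cc1)N1CCc2ccccc2C1` differs from compound 1 by one change: naphthalen-2-yl in place of 4-methylphenyl on an oxygen on a saturated carbon. Going by the values given here, no measured step gives a readable size for a change of this kind, and the values of compound 1, compound 2 and compound 3 all end at the limit. The expectation for compound 4 is thus no step beyond the scatter, the estimated step being a number no higher from compound 1 to compound 4 (the limit leaves the size open). Compound 4 is expected to give about 50 ug/mL in this assay, within 25 ug/mL to 100 ug/mL, most likely again reported only as a limit.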

Compound 4, half-maximal inhibitory concentration: > 50 ug/mL
Compound 4: only a limit was reported; the forecaster's own chance of this, stated with the estimate: 75%; the middle value lies on the limit itself.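

Compound 4 and compound 1 both end at a limit of the assay in this assay, so no step can be read between them, and the series as a whole stays there: the limit of > 50 ug/mL in this assay, at which 4 of the 4 values shown sit.

The compounds shown leave open how far any of them lies past the limit, and whether any aryl ether on these cores gives a readable value.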